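The source may hold more compounds than are shown below. What is called first, only, known or untested is meant among the compounds shown, and "the series" means these compounds.

Measured compounds in an assay on isolated protein for inhibition of Amine oxidase [flavin-containing] B (Homo sapiens); on this read-out lower numbers stand for stronger inhibition and higher numbers for weaker inhibition:
- compound 1 `C#CCNC1CCc2c(SCc3ccc(Br)cc3)cccc21` gives 1310 nM
- compound 2 `C#CCNC1CCc2c(SCc3ccc(C(F)(F)F)cc3)cccc21` gives 9680 nM

Compound 1 gives the lowest of the two numbers; its nearest neighbour is compound 2, reached by a 7.4-fold higher number from compound 1 to compound 2 (0.87 log units; beyond the scatter), a step that comes from trifluoromethyl in place of bromo on an aromatic carbon. The new compound 3 `C#CCNC1CCc2c(SCc3cccc(Cl)c3)cccc21` differs from compound 1 by 3-chlorophenyl in place of 4-bromophenyl on a saturated chain carbon bound to a sulfur. For the measured compounds named here, no measured step covers this exact change: the only step known, from compound 1 to compound 2, swaps the group on the ring while keeping its position, whereas compound 3 both changes the halogen and moves it to another carbon of the ring. That single step was modest in size and ran towards weaker inhibition, which is taken as the nearest guide. Compound 3 is therefore expected to give a number somewhat higher than compound 1, by a step of a 1.7-fold higher number from compound 1 to compound 3 (0.23 log units; within the scatter), with the chance that the change stays within the scatter. The estimate for compound 3 in this assay is 2200 nM, expected between 700 nM and 7000 nM.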

Compound 3, half-maximal inhibitory concentration: 23300 nM
The estimate for compound 3 lay 11-fold (1.02 log units) below the measured number; the whole stated range lies below it.
By their numbers in this assay, from the lowest: compound 1; then compound 2; then compound 3.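

In this assay, the step of an 18-fold higher number from compound 1 to compound 3 (1.25 log units; beyond the scatter) is large, whereas the earlier step of a 7.4-fold higher number from compound 1 to compound 2 (0.87 log units; beyond the scatter) was modest, so the substituted ring on the saturated chain carbon bound to a sulfur can shift the number much further than the first pair showed. This happens although 4-bromophenyl and 3-chlorophenyl have the same heavy-atom count and neither carries a net charge, so those counts do not track the result here. Both replacements of 4-bromophenyl gave higher numbers, and compound 1 remains the lowest of the three, but this change swaps the halogen and moves it at once, so the step cannot be assigned to either alteration alone. Nothing available explains why the step is so large.

The compounds shown leave open whether the identity of the halogen or its place on the ring matters more, a question that a chloro group kept where compound 1 carries its bromo would help to answer. They also leave open how a plain phenyl, or a ring bearing an amine or a carboxylic acid, would read in this assay.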